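The source may report more compounds than this note shows. Statements on the series, on what has been measured and on what is new or still open speak of the compounds shown alone.

Measured in a functional assay on HepG2 cells (Homo sapiens) for inhibition, read by MTT assay; on this read-out higher numbers stand for weaker inhibition and lower numbers for stronger inhibition:
Compound 1 `COc1cc2ncnc(Nc3ccc(NC(=O)c4ccccc4OC)cc3)c2cc1OC`: > 100000 nM
Compound 2 `CCc1ccc(C(=O)Nc2ccc(Nc3ncnc4cc(OC)c(OC)cc34)cc2)cc1`: 72000 nM
Compound 3 `COc1cc2ncnc(Nc3ccc(NC(=O)c4cccc(Cl)c4)cc3)c2cc1OC`: 12000 nM

Compound 1 stands at > 100000 nM, which is a limit of the assay and not a number. Of the two true numbers, compound 3 has the lower, and compound 2 is its nearest neighbour.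

The next compound, compound 4 `COc1cc2ncnc(Nc3ccc(NC(=O)c4ccc(I)cc4)cc3)c2cc1OC`, carries 4-iodophenyl in place of 3-chlorophenyl on a carbonyl carbon. Two measured steps change the same group at this place. One is a 6.0-fold lower number from compound 2 to compound 3 (0.78 log units; beyond the scatter), and the other is an at least 8.3-fold lower number from compound 1 to compound 3 (0.92 log units; beyond the scatter). Compound 2 is the closest measured model for the entering group, since its 4-ethylphenyl also bears a 4-substituent, so part of a 6.0-fold lower number from compound 2 to compound 3 (0.78 log units; beyond the scatter) is expected to be reversed in this assay. The estimated change is a 2.5-fold higher number from compound 3 to compound 4 (0.40 log units; beyond the scatter), a modest move to a higher number. For compound 4 the expected value is 30000 nM, with an estimated range from 9000 nM to 100000 nM.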

Compound 4, half-maximal inhibitory concentration: 40000 nM
Estimate against measurement, compound 4: 1.3-fold (0.12 log units) below, within the range that was stated.
By their numbers in this assay, from the lowest: compound 3; then compounds 4 and 2 (each within the scatter of the next). At a limit, above all of these: compound 1.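

In this assay, the 4-iodophenyl group does not keep the gain seen with 3-chlorophenyl on this carbonyl carbon (a 3.3-fold higher number from compound 3 to compound 4 (0.52 log units; beyond the scatter)), so compound 3 still has the lowest number of the series. Iodo in place of ethyl on the aromatic carbon makes no change beyond the scatter (a 1.8-fold lower number from compound 2 to compound 4 (0.26 log units; within the scatter)), so compound 2 and compound 4 cannot be told apart here. Compound 1 remains a limit of the assay and not a number, so its step gives only a floor (an at least 2.5-fold lower number from compound 1 to compound 4 (0.39 log units; beyond the scatter)), and it rests on this: the limit of > 100000 nM in this assay, at which 1 of the 4 values shown sits.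

Since 3-chlorophenyl and 4-iodophenyl differ in both the halogen and its place on the ring, the compounds shown cannot separate those two changes; 4-chlorophenyl would bear on this. From the compounds shown here alone, how an amine or a carboxylic acid on that ring would read also stays open.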